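The compounds below may be only part of what the source reports. "The series", "measured", "known", "first", "only" and "open" are said of these compounds alone.

Of the compounds shown here, two built on the same core have been tested in a functional assay on CCRF-CEM cells (Homo sapiens); a higher number here means a weaker inhibitor, a lower number a stronger inhibitor. Compound 1 `CN(C)CC1CCC/C(=C\c2ccc(OC(=O)/C=C/c3ccccc3)cc2)C1=O` carries no halogen, and in this assay compound 1 gives 42800 nM. Compound 2 `CN(C)CC1CCC/C(=C\c2ccc(OC(=O)/C=C/c3ccc(Br)cc3)cc2)C1=O` differs from it only by a bromo in place of hydrogen on an aromatic carbon, and in this assay compound 2 gives 4440 nM. Among the compounds with values here, that single change gave a 9.6-fold lower number from compound 1 to compound 2 (0.98 log units; beyond the scatter), so compound 2 holds the lower of the two numbers so far, with compound 1 its only point of comparison.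

Compound 3 `CN(C)CC1CCC/C(=C\c2ccc(OC(=O)/C=C/c3ccc(Cl)c(Cl)c3)cc2)C1=O` has not yet been measured. Its difference from compound 2 is 3,4-dichlorophenyl in place of 4-bromophenyl on a double-bonded chain carbon bound to a double-bonded chain carbon. Within the data shown here, the only step that bears on this is a 9.6-fold lower number from compound 1 to compound 2 (0.98 log units; beyond the scatter), which shows that adding a halogen lowered the number considerably. Compound 3 keeps halogens on that part of the molecule, two chlorines in place of one bromine, so a number near that of compound 2, perhaps somewhat lower, is expected rather than a large shift in either direction. The estimate for compound 3 in this assay is 3000 nM, with a likely range from 1000 nM to 9000 nM. This corresponds to an expected step of a 1.5-fold lower number from compound 2 to compound 3 (0.17 log units; within the scatter).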

Compound 3, half-maximal inhibitory concentration: 5820 nM
Beside the measured number, compound 3's estimate is 1.9-fold (0.29 log units) below it; low and high end bracket the measured number.
By their numbers in this assay, from the lowest: compounds 2 and 3 (each within the scatter of the next); then compound 1.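

In this assay, replacing 4-bromophenyl with 3,4-dichlorophenyl gives a 1.3-fold higher number from compound 2 to compound 3 (0.12 log units; within the scatter), so the two halogen-bearing rings cannot be told apart at this position. Measured against the plain phenyl of compound 1, the new group gives a 7.4-fold lower number from compound 1 to compound 3 (0.87 log units; beyond the scatter), which shows that the lower number first seen with bromine also appears with a different halogen and a different substitution pattern on the ring. Across these three compounds, then, both halogen-bearing rings sit well under the plain phenyl, and neither has a measurable edge over the other, though nothing available explains why the two give such similar numbers.

All the substituents shown on this ring are halogens, so it remains open whether a methoxy group, a nitrile or an amine on the same ring would also bring the number down to the level of compound 2 and compound 3. From the compounds shown here alone, it is also open how a single chlorine or a single fluorine would compare in this assay, which would help separate the effect of the kind of halogen from that of the substitution pattern.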